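The source may report more compounds than this note shows. Statements on the series, on what has been measured and on what is new or still open speak of the compounds shown alone.

Compound 1, `COCCOC1CCN(c2nc(N)c3cc(OC)c(OC)cc3n2)CC1`: in an assay on brain for displacement of a labelled ligand from Adrenergic receptor alpha-1 (Rattus norvegicus) (on this read-out higher numbers stand for weaker inhibition and lower numbers for stronger inhibition), compound 1 gives 2.12 nM
Compound 2, `CCCCOCCOC1CCN(c2nc(N)c3cc(OC)c(OC)cc3n2)CC1`: compound 2 gives 1.03 nM
Compound 3, `COc1cc2nc(N3CCC(OCCOc4ccccc4)CC3)nc(N)c2cc1OC`: compound 3 gives 0.48 nM

Among these three, compound 3 gives the lowest number. Its nearest neighbour is compound 2 (a 2.1-fold lower number from compound 2 to compound 3 (0.33 log units; beyond the scatter)), and the furthest is compound 1 (a 4.4-fold lower number from compound 1 to compound 3 (0.65 log units; beyond the scatter)).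

Compound 4, `COc1cc2nc(N3CCC(OCCO)CC3)nc(N)c2cc1OC`, has not yet been measured in this assay. It differs from compound 3 in one place: hydrogen in place of phenyl on an oxygen on a saturated carbon. Cut one bond further out, the phenoxy of compound 3 becomes a hydroxy, and the 2-phenoxyethyl becomes a 2-hydroxyethyl.

Among the compounds with values here, two measured steps bear directly on this change, both running the other way: from methyl to phenyl (a 4.4-fold lower number from compound 1 to compound 3 (0.65 log units; beyond the scatter)) and from butyl to phenyl (a 2.1-fold lower number from compound 2 to compound 3 (0.33 log units; beyond the scatter)). A third step, on the neighbouring saturated chain carbon, also points the same way (a 2.1-fold lower number from compound 1 to compound 2 (0.31 log units; beyond the scatter)). Every enlargement of the group on this oxygen has lowered the number, so removing the phenyl altogether is expected to raise it. Within the data shown here, no compound in the set carries a bare hydroxy at this place, so the size of the step is uncertain; since hydrogen is smaller than the methyl of compound 1, a number beyond that of compound 1 seems likely. The expected step is a 9.4-fold higher number from compound 3 to compound 4 (0.97 log units; beyond the scatter). Compound 4 is therefore estimated at 4.5 nM, with a range from 1.5 nM to 14 nM.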

Compound 4, inhibition constant: 2.2 nM
Estimate against measurement, compound 4: 2.0-fold (0.31 log units) above, and the stated range covers the measured number.
By their numbers in this assay, from the lowest: compound 3; then compound 2; then compounds 1 and 4 (each within the scatter of the next).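

At this oxygen in this assay, hydrogen in place of phenyl gives a 4.6-fold higher number from compound 3 to compound 4 (0.66 log units; beyond the scatter) and hydrogen in place of butyl gives a 2.1-fold higher number from compound 2 to compound 4 (0.33 log units; beyond the scatter), so the bare hydroxy stands apart from both larger groups, as the methyl ether did. What is new lies at the small end of the series: hydrogen in place of methyl gives a 1.0-fold higher number from compound 1 to compound 4 (0.02 log units; within the scatter), so the earlier run, in which each larger group went with a lower number, does not continue from methyl down to hydrogen, and this pair is the exception to it. Even with only hydrogen on this oxygen, compound 4 still gives 2.2 nM, so the butyl and phenyl groups lower a number that is already small without them.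

No measurement at hand accounts for these differences. The compounds shown also leave open whether an amine or a carboxylic acid in place of the hydroxy, or a benzyl group or a longer chain on this oxygen, would fall with the phenyl of compound 3 or with the methyl of compound 1.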